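From compound 3 to compound 4: a second ring methyl

The source may report more compounds than this note shows. Statements on the series, on what has been measured and on what is new or still open speak of the compounds shown alone.

In a functional assay on DU-145 cells (Homo sapiens) for inhibition, read by CCK-8 assay, with a stated time of 72 h (on this read-out higher numbers stand for weaker inhibition and lower numbers for stronger inhibition), compound 1 `O=C(/C=C/c1cccnc1)NCCCCCCc1cccc(S(=O)(=O)Nc2ccccc2)c1` gives 6.73 nM, compound 2 `Cc1ccccc1NS(=O)(=O)c1cccc(CCCCCCNC(=O)/C=C/c2cccnc2)c1` gives 2.9 nM and compound 3 `Cc1cccc(NS(=O)(=O)c2cccc(CCCCCCNC(=O)/C=C/c3cccnc3)c2)c1` gives 41.7 nM, the highest of the three numbers and so the weakest inhibition so far. Compound 4 `Cc1ccc(C)c(NS(=O)(=O)c2cccc(CCCCCCNC(=O)/C=C/c3cccnc3)c2)c1` is still unmeasured. Its difference from compound 3 is methyl in place of hydrogen on an aromatic carbon, a methyl in place of hydrogen on an aromatic carbon, ortho to a large group and para to a methyl group, which turns 3-methylphenyl into 2,5-dimethylphenyl.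

Among the compounds with values here, the closest precedent is a 2.3-fold lower number from compound 1 to compound 2 (0.37 log units; beyond the scatter), a modest step that brings in 2-methylphenyl. The methyl already on compound 3 stays in place, and its own entry was a 6.2-fold higher number from compound 1 to compound 3 (0.79 log units; beyond the scatter). The large 14-fold higher number from compound 2 to compound 3 (1.16 log units; beyond the scatter) shows that the two single-methyl compounds sit far apart in this assay. Within the data shown here, no measured compound yet carries two methyls on this ring, so whether the two steps add is open. If they do, a modest move towards stronger inhibition follows, of about the size seen for compound 2 a 2.3-fold lower number from compound 1 to compound 2 (0.37 log units; beyond the scatter). The expected change is a 2.3-fold lower number from compound 3 to compound 4 (0.36 log units; beyond the scatter). For compound 4 the estimated value is 18 nM, with an expected range from 5 nM to 60 nM.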

Compound 4, half-maximal inhibitory concentration: 7.48 nM
For compound 4 the middle estimate is 2.4-fold (0.38 log units) above the measured one, and the stated range covers the measured number.
By their numbers in this assay, from the lowest: compound 2; then compounds 1 and 4 (each within the scatter of the next); then compound 3.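

On the 3-methylphenyl ring, methyl in place of hydrogen ortho to a large group gives a 5.6-fold lower number from compound 3 to compound 4 (0.75 log units; beyond the scatter) in this assay, the same direction as the matching change on the phenyl ring, and the two sizes agree: the same change on two cores in this assay, a 2.3-fold lower number (0.37 log units; beyond the scatter) from compound 1 to compound 2 and a 5.6-fold lower number (0.75 log units; beyond the scatter) from compound 3 to compound 4, 2.4-fold (0.38 log units) apart, within the scatter of two such steps. The other methyl also keeps its direction when the first methyl is already present, with a 2.6-fold higher number from compound 2 to compound 4 (0.41 log units; beyond the scatter) pointing the same way as its earlier step: the same change on two cores in this assay, a 6.2-fold higher number (0.79 log units; beyond the scatter) from compound 1 to compound 3 and a 2.6-fold higher number (0.41 log units; beyond the scatter) from compound 2 to compound 4, 2.4-fold (0.38 log units) apart, within the scatter of two such steps. The two methyl steps therefore add within the scatter across these four compounds, and their opposite directions leave the doubly substituted ring level with phenyl, as a 1.1-fold higher number from compound 1 to compound 4 (0.05 log units; within the scatter) shows.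

As far as these compounds go, whether this additivity extends beyond methyl remains open, for instance with an ethyl, a methoxy or a chlorine ortho to the large group. From the compounds shown here alone, it is also open whether the same pattern holds on a core with a shorter or longer linking chain.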